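Oxiran-2-yl added to the methoxy group of compound 3

The compounds below may be only part of what the source reports. "The series", "measured", "known", "first", "only" and "open" are said of these compounds alone.

In a functional assay on NCI-H520 cells (Homo sapiens) for cytotoxicity (a higher number here means a weaker inhibitor of growth, a lower number a stronger inhibitor of growth), compound 3 (`COc1ccc(C2=C(c3ccc(SC)cc3)CC3CCCN3C2=O)cc1`) gives 800 nM, the middle of three numbers: compound 1 (`COc1ccc(C2=C(c3ccc(SC)cc3)CC3CCCN3C2=O)cc1C`) gives 100 nM and compound 2 (`CSc1ccc(C2=C(c3ccc(O)c(O)c3)C(=O)N3CCCC3C2)cc1`) gives 60000 nM. Compound 4 (`CSc1ccc(C2=C(c3ccc(OCC4CO4)cc3)C(=O)N3CCCC3C2)cc1`) turns methoxy into (oxiran-2-yl)methoxy: oxiran-2-yl in place of hydrogen on a saturated chain carbon bound to an oxygen on an aromatic ring. Among the compounds with values here, no measured step alters this chain. The nearest evidence comes from changes to the same aryl group: a 75-fold lower number from compound 2 to compound 3 (1.88 log units; beyond the scatter), which is large, and an 8.0-fold higher number from compound 1 to compound 3 (0.90 log units; beyond the scatter), which is modest. Both show that this assay responds to changes on that group, but neither gives the direction for this one. A modest move to a higher number is expected, with low confidence. The expected step is a 2.5-fold higher number from compound 3 to compound 4 (0.40 log units; beyond the scatter). The estimate for compound 4 is 2000 nM, within an expected range of 500 nM to 10000 nM.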

Compound 4, concentration for 50% growth inhibition: 30 nM
Compound 4: the middle estimate sits 67-fold (1.82 log units) above what was measured; measured number outside the range, below it.
By their numbers in this assay, from the lowest: compound 4; then compound 1; then compound 3; then compound 2.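

In this assay, (oxiran-2-yl)methoxy in place of methoxy gives a 27-fold lower number from compound 3 to compound 4 (1.43 log units; beyond the scatter), so a substituent on this saturated chain carbon bound to an oxygen on an aromatic ring goes with stronger growth inhibition. Within the data shown here, the earlier steps showed only that this aryl group matters, and none touched this chain. Nothing available explains the size of this step. The compounds shown leave open whether the oxiran-2-yl ring itself or simply a longer chain accounts for the step. A cyclopropyl group or an open-chain diol on this carbon would separate the two.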